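Replacing butyl with fluorophenyl on the amino nitrogen

The compounds below may be only part of what the source reports. "The series", "measured", "known", "first", "only" and "open" are said of these compounds alone.

Compound 3 `CCCCNc1cccc(NC(=O)c2ccc(OCCC)cc2)n1` gives 54100 nM in an in vitro assay on HEK-tsA201 cells for antagonist activity at Neuronal acetylcholine receptor; alpha4/beta2 (Homo sapiens), read by fluorescence and calcium flux (on this read-out higher numbers stand for weaker inhibition and lower numbers for stronger inhibition), the higher of the two numbers recorded there, while compound 1 `C=CCOc1ccc(C(=O)Nc2ccccn2)cc1` gives 19300 nM. Compound 2 `C=CCOc1ccc(C(=O)Nc2cccc(Cl)n2)cc1` reaches only a limit of this assay, > 100000 nM. For the measured compounds named here, the one measured step, an at least 5.1-fold higher number from compound 1 to compound 2 (0.71 log units; beyond the scatter), concerns a chloro group on the core and not the amino substituent that changes here; it therefore offers no guide. Compound 4 `CCCOc1ccc(C(=O)Nc2cccc(Nc3ccc(F)cc3)n2)cc1` differs from compound 3 by 4-fluorophenyl in place of butyl on a nitrogen on an aromatic ring. Going by the values given here, with no measured step bearing on this change, a number close to that of compound 3 is expected, with a 1.1-fold lower number from compound 3 to compound 4 (0.03 log units; within the scatter) as the estimated step. Compound 4 is estimated at 50000 nM, within 15000 nM to 150000 nM.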

Compound 4, half-maximal inhibitory concentration: > 100000 nM
Compound 4 was reported as a limit; the forecaster's own chance of this, stated with the estimate: 30%; middle value at least 2.0-fold (0.30 log units) away from the limit.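

Compound 4 gives > 100000 nM in this assay, which is a limit and not a number: the limit of > 100000 nM in this assay, at which 2 of the 4 values shown sit. Among the compounds shown, this is the first change on the amino nitrogen, and 4-fluorophenyl in place of butyl brings no stronger inhibition, with an at least 1.8-fold higher number from compound 3 to compound 4 (0.26 log units; that floor lies within the scatter). Since that floor lies within the scatter, the true size of the step cannot be read.

On these data alone, how far compound 4 lies past the limit remains open. So does whether an ethyl group, a benzyl group or a morpholine ring at this place would give stronger inhibition than butyl.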